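A few compounds are considered here, and "the series" means these few. Any claim that something is new, unique, unknown or untested is made for them only; others in the source may bear on it.

Measured compounds:
compound 1 `CCS(=O)(=O)Nc1cc(C2CCCCC2)cc2c1CCCC2c1c[nH]cn1`, 269 nM
compound 2 `CC(=O)Nc1cccc2c1CCCC2c1c[nH]cn1`, 525 nM
compound 3 `CCS(=O)(=O)Nc1cccc2c1CCCC2CNC`, 1380 nM

The three compounds were read in an assay on isolated protein for binding affinity to Alpha-1A adrenergic receptor (Rattus norvegicus), read by radioligand binding; a higher number here means a weaker inhibitor, a lower number a stronger inhibitor. Compound 1 has the lowest of the three numbers, at 269 nM. Compound 2 sits nearest to it, at 525 nM, a gap within the scatter, so no order between compound 1 and compound 2 can be claimed. Compound 3, at 1380 nM, lies furthest from compound 1, and that gap is beyond the scatter; compound 3 differs from compound 1 in more than one place, so the two values are reported without a step between them.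

Compound 4 `CCS(=O)(=O)Nc1cc(F)cc2c1CCCC2c1c[nH]cn1` is not yet measured in this assay. It differs from compound 1 in one place: fluoro in place of cyclohexyl on an aromatic carbon. Among the compounds with values here, no pair of measured compounds shows this change on its own, so the size of the step has to be estimated. Compound 2, which carries no group at that aromatic carbon, gives 525 nM, within the scatter of compound 1 but differing elsewhere as well. The step from compound 1 to compound 4 is expected to be small, toward a somewhat higher number, a 2.0-fold higher number from compound 1 to compound 4 (0.31 log units; beyond the scatter), though it may fall within the scatter. Compound 4 is therefore expected to give about 550 nM in this assay, with a range from 170 nM to 1800 nM.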

Compound 4, inhibition constant: 83.2 nM
Compound 4: the middle estimate sits 6.6-fold (0.82 log units) above what was measured; measured number outside the range, below it.
By their numbers in this assay, from the lowest: compound 4; then compounds 1 and 2 (each within the scatter of the next); then compound 3.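

In this assay, within the data shown here, this aromatic carbon, meta to the (ethylsulfonyl)amino group and para to a fused ring, gives the first single change that can be read: fluoro in place of cyclohexyl produces a 3.2-fold lower number from compound 1 to compound 4 (0.51 log units; beyond the scatter) and so moves the number beyond the scatter. The cyclohexyl ring is therefore not required at this carbon for the affinity seen with compound 1, since a group of 1 heavy atom in place of one with 6 heavy atoms goes with the lower number. Nothing shown bears on the reason for this step.

A hydrogen at this carbon would separate the loss of cyclohexyl from the arrival of fluoro, while chloro, methoxy or a short chain such as ethyl would show whether the lower number extends to other small groups. Going by these compounds, it also remains open whether fluoro at this carbon would move the number in the same direction alongside the other groups carried by compound 2 and compound 3.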